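Notes on compound 4: chloro to methyl exchange

The compounds below may be only part of what the source reports. "The series", "measured", "known", "first", "only" and "open" are said of these compounds alone.

Measured in a functional assay on HEK293 cells for antagonist activity at transient receptor potential cation channel subfamily V member 1 (Rattus norvegicus); a higher number here means a weaker inhibitor, a lower number a stronger inhibitor:
compound 1, `Cc1ccc(NC(=O)N2CCN(c3ncccc3C(F)(F)F)CC2)cc1`: 556 nM
compound 2, `CC(C)(C)c1ccc(NC(=O)N2CCN(c3ncccc3C(F)(F)F)CC2)cc1`: 11.3 nM
compound 3, `CC(C)c1ccc(NC(=O)N2CCN(c3ncccc3Cl)CC2)cc1`: 11.5 nM

Going by the values given here, compound 3 stands second highest of the three numbers; its value lies with that of compound 2 within the scatter and far from compound 1, the only counted step being a 49-fold lower number from compound 1 to compound 2 (1.69 log units; beyond the scatter). Among the compounds with values here, compound 2 and compound 3 differ in two places, so no step is counted between them; their two values simply lie together.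

Compound 4, `Cc1cccnc1N1CCN(C(=O)Nc2ccc(C(C)C)cc2)CC1`, differs from compound 3 by methyl in place of chloro on an aromatic carbon. Within the data shown here, the step from compound 1 to compound 2 alters the other aromatic ring and does not touch the position changed here, so no measured step bears directly on it. Compound 2 and compound 3 carry trifluoromethyl and chloro at the 3-chloropyridin-2-yl side and give values within the scatter of each other, which suggests this position tolerates exchange, though it is not a counted step. Compound 4 is therefore expected close to compound 3, the estimated step of a 1.7-fold higher number from compound 3 to compound 4 (0.24 log units; within the scatter) lying within the scatter. The estimate for compound 4 is 20 nM, with a range from 7 nM to 60 nM.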

Compound 4, half-maximal inhibitory concentration: 25.3 nM
Compound 4: the middle estimate sits 1.3-fold (0.10 log units) below what was measured; the range from low to high includes it.
By their numbers in this assay, from the lowest: compounds 2 and 3 (each within the scatter of the next); then compound 4; then compound 1.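

In this assay, going by these compounds alone, the first counted step at the 3-chloropyridin-2-yl position is a 2.2-fold higher number from compound 3 to compound 4 (0.34 log units; beyond the scatter), so this position is not indifferent to the exchange of chloro for methyl, a point the earlier compounds could only leave open. The step is modest and much smaller than the one on the other aromatic ring, a 49-fold lower number from compound 1 to compound 2 (1.69 log units; beyond the scatter), so the series has so far shown more change at that ring than here. No measurement in hand gives an explanation for the loss on going from chloro to methyl.

On these data alone, whether an amine or methoxy at this position would fall nearer to chloro or to methyl remains open. As far as these compounds go, it is also open whether the same step would appear with tert-butyl rather than isopropyl on the other aromatic ring.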